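Thiophen-3-yl in Place of Furan-3-yl: an Expectation

This account rests on a few compounds, and the source may have more. Where it says the series, first, only, none or still open, it means among the compounds named here.

Measured compounds in an assay on membranes from CHO cells for displacement of a labelled ligand from adenosine receptor A1 (Homo sapiens), read by scintillation counting, with a stated time of 60 min, tested at 1 uM; a lower number here means less inhibition, a higher number more inhibition at the concentration tested (going by the name of the read-out):
compound 1 `CC1=C(C(=O)NC(C)C)C(c2ccsc2)NC(=O)N1` gives 8%
compound 2 `CC1=C(C(=O)OC2CCCC2)C(c2ccoc2)NC(=O)N1` gives 6%

In this assay compound 2 stands at the smaller of the two numbers shown, yet compound 1 lies only a little higher, within the usual scatter, so the two cannot be told apart. Compound 3 `CC1=C(C(=O)OC2CCCC2)C(c2ccsc2)NC(=O)N1` differs from compound 2 by thiophen-3-yl in place of furan-3-yl on a saturated ring carbon. Within the data shown here, no step between measured compounds bears on this change, so no shift beyond the scatter is expected in this assay. Compound 3 is therefore estimated at 8%, with a range from 0% to 20%. The expected step of a number 2 percentage points higher from compound 2 to compound 3 (within the scatter) is within the scatter.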

Compound 3, a percentage reported as inhibition, at one concentration (the size of the read-out at that concentration, not a potency): 5%
Compound 3: middle estimate off by 3 percentage points, on the high side; low and high end bracket the measured number.
By their numbers in this assay, from the lowest: compounds 3, 2 and 1 (each within the scatter of the next).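

In this assay, thiophen-3-yl in place of furan-3-yl on a saturated ring carbon gives a number 1 percentage points lower from compound 2 to compound 3 (within the scatter), the first step read at this position, so this exchange cannot be told from no change. Cyclopentyloxy in place of isopropylamino on a carbonyl carbon gives a number 3 percentage points lower from compound 1 to compound 3 (within the scatter), so that exchange cannot be told from no change either. Nothing given here accounts for either step.

Going by these compounds, whether a phenyl group on that saturated ring carbon, or an amine or a longer chain in place of cyclopentyloxy, would shift the number beyond the scatter stays open.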